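A few compounds are considered here, and "the series" means these few. Any claim that something is new, unique, unknown or untested is made for them only; others in the source may bear on it.

Working notes on the series, read in a functional assay on brain (Rattus norvegicus, strain Wistar) for inhibition; a higher number here means a weaker inhibitor, a lower number a stronger inhibitor. Compound 1 `CCCc1ccc(-c2c(C)[nH]c(=O)n2C2CCCCC2)cc1` gives the first reading (13900 nM). Compound 2 `Cc1[nH]c(=O)n(C2CCCCC2)c1-c1ccc(CC(C)C)cc1` gives the second (10900 nM). Compound 3 `Cc1[nH]c(=O)n(C2CCCCC2)c1-c1ccc(OCCC(C)C)cc1` gives the third (7200 nM). All three values lie within the scatter of one another, so compound 3 stands level with the other two.

Compound 4 `CCCCCCCc1ccc(-c2c(C)[nH]c(=O)n2C2CCCCC2)cc1` is not yet measured. Its difference from compound 3 is heptyl in place of isopentyloxy on an aromatic carbon, para to a large group (heptyl in place of isopentyloxy on an aromatic carbon).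

For the measured compounds named here, three measured steps bear on this change: (a 1.9-fold lower number from compound 1 to compound 3 (0.29 log units; within the scatter)), (a 1.5-fold lower number from compound 2 to compound 3 (0.18 log units; within the scatter)) and (a 1.3-fold lower number from compound 1 to compound 2 (0.11 log units; within the scatter)). Going by the values given here, all are small and stay within the scatter, although no measured compound carries a chain as long as heptyl. From the compounds shown here alone, no step beyond the scatter is therefore expected in this assay, and the direction stays open. The expected step is small (a 1.0-fold lower number from compound 3 to compound 4 (0.01 log units; within the scatter)). Compound 4 is estimated at 7000 nM with 2500 nM to 20000 nM as the expected range.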

Compound 4, half-maximal inhibitory concentration: 8700 nM
Compound 4: middle estimate off by 1.2-fold (0.09 log units), on the low side; low and high end bracket the measured number.
By their numbers in this assay, from the lowest: compounds 3, 4, 2 and 1 (each within the scatter of the next).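

In this assay, heptyl on this aromatic carbon, para to a large group, brings the longest chain of the series yet gives no step beyond the scatter against isopentyloxy (a 1.2-fold higher number from compound 3 to compound 4 (0.08 log units; within the scatter)). The same holds against the branched and short chains (a 1.3-fold lower number from compound 2 to compound 4 (0.10 log units; within the scatter); a 1.6-fold lower number from compound 1 to compound 4 (0.20 log units; within the scatter)), so across the four compounds neither chain length, branching nor the oxygen of isopentyloxy separates the readings. No supporting data bear on why this position tolerates these chains.

The compounds shown leave open whether an amine or a carboxylic acid at this position, or a chain longer than heptyl, would give a step beyond the scatter. They also leave open whether a change elsewhere on the shared core would move the number further than any change at this position has.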